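This account rests on a few compounds, and the source may have more. Where it says the series, first, only, none or still open, it means among the compounds named here.

Measured compounds: compound 1 `Cc1cc(C)c(S(C)(=O)=O)cc1C(=O)N=C(N)N` gives 11 nM in a functional assay for inhibition of sodium/hydrogen exchanger (Oryctolagus cuniculus); a higher number here means a weaker inhibitor, a lower number a stronger inhibitor; compound 2 `COc1cc(C)c(C(=O)N=C(N)N)cc1S(C)(=O)=O` gives 16 nM; compound 3 `Cc1cc(N2CCC(N)CC2)c(S(C)(=O)=O)cc1C(=O)N=C(N)N` gives 9.8 nM.

The change from compound 1 to compound 2 is methoxy in place of methyl on an aromatic carbon and gave a 1.5-fold higher number from compound 1 to compound 2 (0.16 log units; within the scatter). Compound 4 `COc1cc(N2CCC(N)CC2)c(S(C)(=O)=O)cc1C(=O)N=C(N)N` is made from compound 3 by methoxy in place of methyl on an aromatic carbon; its core differs from that of compound 1 by 4-aminopiperidin-1-yl in place of methyl on an aromatic carbon. The two places are not the same: in compound 1 the change sits ortho to a methylsulfonyl group, meta to a methyl group and para to a group of 6 heavy atoms, while in compound 3 it sits ortho to a group of 6 heavy atoms, meta to a 4-aminopiperidin-1-yl group and para to a methylsulfonyl group, so it is the same kind of change, not the same change. A step of a 1.3-fold higher number from compound 3 to compound 4 (0.12 log units; within the scatter) is expected for compound 4, resting on the small step from compound 1 to compound 2 of a 1.5-fold higher number from compound 1 to compound 2 (0.16 log units; within the scatter). Compound 4 is estimated at 13 nM, between 6 nM and 30 nM.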

Compound 4, half-maximal inhibitory concentration: 73 nM
Estimate against measurement, compound 4: 5.6-fold (0.75 log units) below; measured number outside the range, above it.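

In this assay, methoxy in place of methyl gave a step beyond the scatter on the core of compound 3 (a 7.4-fold higher number from compound 3 to compound 4 (0.87 log units; beyond the scatter)), so the step seen on the core of compound 1 did not carry over in size. The two steps differ: the same change on two cores in this assay, a 1.5-fold higher number (0.16 log units; within the scatter) from compound 1 to compound 2 and a 7.4-fold higher number (0.87 log units; beyond the scatter) from compound 3 to compound 4, 5.1-fold (0.71 log units) apart, beyond the scatter of two such steps. This shows that, for these two pairs, the size of the step depends on the core, but with one pair per core it does not show what in the core sets that size or how the change would behave on any further core.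

The compounds shown leave open whether the larger step belongs to the 4-aminopiperidin-1-yl group specifically or would also appear with a simple open-chain amine or a longer chain in its place. They also leave open whether ethoxy or chlorine in place of methoxy would give a similar step on the core of compound 3.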